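The source may report more compounds than this note shows. Statements on the series, on what has been measured and on what is new or still open speak of the compounds shown alone.

Measured in an ADME assay on HEK-293T cells (Homo sapiens) for cytotoxicity, read by MTT assay, with a stated time of 24 h; on this read-out lower numbers stand for higher toxicity in this test and higher numbers for lower toxicity in this test:
Compound 1 `Cc1ccc(-c2nn(-c3ccccc3)cc2-c2nc3ccccc3n2S(=O)(=O)c2ccc(Cl)cc2)cc1` gives 167000 nM.
Compound 2 `Cc1ccc(-c2nn(-c3ccccc3)cc2-c2nc3ccccc3n2S(=O)(=O)c2ccc(Br)cc2)cc1` gives 159000 nM.
Compound 3 `O=S(=O)(c1ccc(Cl)cc1)n1c(-c2cn(-c3ccccc3)nc2-c2ccc(C(F)(F)F)cc2)nc2ccccc21` gives 75300 nM.

Compound 2 differs from compound 1 by bromo in place of chloro on an aromatic carbon; the step is a 1.1-fold lower number from compound 1 to compound 2 (0.02 log units; within the scatter). Compound 3 differs from compound 1 in its core by trifluoromethyl in place of methyl on an aromatic carbon, and the step is a 2.2-fold lower number from compound 1 to compound 3 (0.35 log units; beyond the scatter), giving compound 3 the lowest number of the three.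

Compound 4 `O=S(=O)(c1ccc(Br)cc1)n1c(-c2cn(-c3ccccc3)nc2-c2ccc(C(F)(F)F)cc2)nc2ccccc21` is not yet measured. It differs from compound 3 by bromo in place of chloro on an aromatic carbon, the same change as from compound 1 to compound 2, at a place described in the same words: on an aromatic carbon of a six-membered aromatic ring of carbon only, para to a large group. Compound 4 is expected to give 72000 nM in this assay, within 36000 nM to 150000 nM. The expected step of a 1.0-fold lower number from compound 3 to compound 4 (0.02 log units; within the scatter) rests on the earlier step of a 1.1-fold lower number from compound 1 to compound 2 (0.02 log units; within the scatter), which lay within the scatter.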

Compound 4, half-maximal cytotoxic concentration: 185000 nM
Beside the measured number, compound 4's estimate is 2.6-fold (0.41 log units) below it; measured number above the stated range.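

In this assay, bromo in place of chloro gives a 2.5-fold higher number from compound 3 to compound 4 (0.39 log units; beyond the scatter), and the gap to the same change on the other core stays within what two such steps scatter: the same change on two cores in this assay, a 1.1-fold lower number (0.02 log units; within the scatter) from compound 1 to compound 2 and a 2.5-fold higher number (0.39 log units; beyond the scatter) from compound 3 to compound 4, 2.6-fold (0.41 log units) apart, within the scatter of two such steps

Trifluoromethyl in place of methyl gives a 1.2-fold higher number from compound 2 to compound 4 (0.07 log units; within the scatter), and its gap also stays within that scatter: the same change on two cores in this assay, a 2.2-fold lower number (0.35 log units; beyond the scatter) from compound 1 to compound 3 and a 1.2-fold higher number (0.07 log units; within the scatter) from compound 2 to compound 4, 2.6-fold (0.41 log units) apart, within the scatter of two such steps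

So no dependence on the core is shown for either change, yet two pairs per change do not establish that either one carries over unaltered.

The compounds shown leave open how fluoro, methoxy or a nitrile would read as a replacement for chloro. They also leave open what an amine or a carboxylic acid in place of trifluoromethyl would give.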